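The source may report more compounds than this note shows. Statements on the series, on what has been measured and on what is new or still open speak of the compounds shown alone.

Compound 1 `CCSc1nc(N)c2nc(O)n(Cc3ccccc3)c2n1` is the starting point of this step. In a functional assay on the whole organism for activation, with Mus musculus as the target (a lower number here means that less compound is needed, a higher number that more compound is needed for the effect), compound 1 gives 0.1 mg/kg, level with compound 3 `CCCSc1nc(N)c2nc(O)n(Cc3ccccc3)c2n1`, which gives 0.1 mg/kg, and together these two are the lowest of the three numbers measured; compound 2 `Nc1nc(O)nc2c1nc(O)n2Cc1ccccc1` gives 1 mg/kg. Compound 4 `COc1nc(N)c2nc(O)n(Cc3ccccc3)c2n1` differs from compound 1 by methoxy in place of ethylsulfanyl on an aromatic carbon. Within the data shown here, two measured steps bear on this: no change at the digits printed from compound 1 to compound 3 (within the scatter), and a 10-fold higher number from compound 1 to compound 2 (1.00 log units; beyond the scatter). Among the measured compounds shown here, no measured pair tests the methoxy group itself. The change to compound 4 replaces the sulfur-linked group with a smaller oxygen-linked group, so compound 4 is expected to land somewhere within the span set by compound 1 and compound 2, that is a 3.0-fold higher number from compound 1 to compound 4 (0.48 log units; beyond the scatter). The estimate for compound 4 is 0.3 mg/kg, with a range from 0.1 mg/kg to 1 mg/kg.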

Compound 4, minimum effective dose: > 1 mg/kg
Compound 4: only a limit was reported (the forecaster's own chance of this, stated with the estimate: 5%); at least 3.3-fold (0.52 log units) between middle value and limit.
By their numbers in this assay, from the lowest: compounds 1 and 3 (each within the scatter of the next); then compound 2.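

In this assay, methoxy on this aromatic carbon between two ring nitrogen atoms does not match the sulfur-linked chains, with an at least 10-fold higher number from compound 1 to compound 4 (1.00 log units; beyond the scatter) and with an at least 10-fold higher number from compound 3 to compound 4 (1.00 log units; beyond the scatter). Compound 4 carries a limit, not a number: the limit of > 1 mg/kg in this assay, at which 1 of the 4 values shown sits. The earlier compounds shown here set ethylsulfanyl level with propylsulfanyl and hydroxy apart from both, whereas compound 4 shows that a short carbon group on this position does not match them when oxygen links it.

Hydroxy and methoxy can be compared only through a number no lower from compound 2 to compound 4 (the limit leaves the size open), so how far methoxy stands from hydroxy stays open. As far as these compounds go, whether methylsulfanyl, propoxy or an amine at this position would match the sulfur-linked chains stays open.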